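Imine Aryl Variation on the Shared Core

This account rests on a few compounds, and the source may have more. Where it says the series, first, only, none or still open, it means among the compounds named here.

Compound 3 `CCOC(=O)c1c(N)sc(/N=C/c2ccc(OC)cc2)c1C(=O)OCC` gives the highest number of the three measured in a functional assay on MCF7 cells (Homo sapiens) for inhibition, read by MTT assay, with a stated time of 48 h (a higher number here means a weaker inhibitor, a lower number a stronger inhibitor), at 16200 nM. Compound 1 `CCOC(=O)c1c(N)sc(/N=C/c2ccccc2)c1C(=O)OCC` gives 6100 nM and compound 2 `CCOC(=O)c1c(N)sc(/N=C/c2ccc(N(C)C)cc2)c1C(=O)OCC` gives 5700 nM; a 2.7-fold higher number from compound 1 to compound 3 (0.42 log units; beyond the scatter) and a 2.8-fold higher number from compound 2 to compound 3 (0.45 log units; beyond the scatter), while a 1.1-fold lower number from compound 1 to compound 2 (0.03 log units; within the scatter). Compound 4 `CCOC(=O)c1c(N)sc(/N=C/c2ccncc2)c1C(=O)OCC` differs from compound 3 by pyridin-4-yl in place of 4-methoxyphenyl on a carbon with a double bond to nitrogen. Within the data shown here, no measured step exchanges the aromatic ring itself; the steps that bear on this change are those from compound 1 and from compound 2 to compound 3, both modest increases, showing that the ring without methoxy gives lower numbers. A modest drop back toward the numbers of compound 1 and compound 2 is therefore expected, a 2.3-fold lower number from compound 3 to compound 4 (0.36 log units; beyond the scatter). Compound 4 is estimated at 7000 nM, within the range 3000 nM to 16000 nM.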

Compound 4, half-maximal inhibitory concentration: 92200 nM
Compound 4: middle estimate off by 13-fold (1.12 log units), on the low side, and the stated range ends below it.
By their numbers in this assay, from the lowest: compounds 2 and 1 (each within the scatter of the next); then compound 3; then compound 4.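

Replacing the whole aromatic ring on the carbon with a double bond to nitrogen moves the number much further than the earlier changes on the phenyl ring did: pyridin-4-yl in place of phenyl gives a 15-fold higher number from compound 1 to compound 4 (1.18 log units; beyond the scatter), and in place of 4-(dimethylamino)phenyl it gives a 16-fold higher number from compound 2 to compound 4 (1.21 log units; beyond the scatter). Against 4-methoxyphenyl the step is smaller, a 5.7-fold higher number from compound 3 to compound 4 (0.76 log units; beyond the scatter), which leaves compound 4 with the highest number of the series in this assay. No measured property accounts for this loss.

Still open, on these data alone, is whether the loss belongs to the ring nitrogen alone. Also open, as far as these compounds go, is how a phenyl ring carrying a carboxylic acid or a primary amine would read on the shared core.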